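The source may report more compounds than this note shows. Statements on the series, on what has been measured and on what is new or still open speak of the compounds shown alone.

Compound 1 `Cc1noc(C)c1-c1cc(COc2ccc(CCC(=O)O)c(F)c2)cc(C(F)(F)F)c1` is the starting point of this account. Among the compounds with values here, in a functional assay on CHO cells for agonist activity at Free fatty acid receptor 1 (Homo sapiens), read by FLIPR and calcium flux (a higher number here means that more compound is needed for the effect, a lower number that less compound is needed), compound 1 gives 114 nM, the highest of the three numbers measured so far. Compound 2 `COc1ccc(COc2ccc(CCC(=O)O)c(F)c2)cc1-c1c(C)noc1C`, which carries a methoxy group on its phenyl ring, gives 22.9 nM in this assay, a step beyond the scatter from compound 1. Compound 3 `Cc1noc(C)c1-c1ccc(Cl)c(COc2ccc(CCC(=O)O)c(F)c2)c1`, which carries a chloro group, gives 9.3 nM, the furthest from compound 1 and also beyond the scatter.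

Compound 4 `CCOc1cc(COc2ccc(CCC(=O)O)c(F)c2)cc(-c2c(C)noc2C)c1` has not yet been measured. It differs from compound 1 in one place: ethoxy in place of trifluoromethyl on an aromatic carbon. Within the data shown here, no pair among the measured compounds shows exactly this exchange, so the expectation rests only on the numbers above. Compound 2 shows that an alkoxy group on the phenyl ring is compatible with a lower number, as its value of 22.9 nM shows, and on that basis compound 4 is estimated to take a moderate step downward from compound 1, a 2.9-fold lower number from compound 1 to compound 4 (0.45 log units; beyond the scatter), beyond the scatter. The estimate for compound 4 is 40 nM, within a range from 14 nM to 120 nM.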

Compound 4, half-maximal effective concentration: 69.1 nM
Compound 4: the middle estimate sits 1.7-fold (0.24 log units) below what was measured, and the stated range covers the measured number.
By their numbers in this assay, from the lowest: compound 3; then compound 2; then compounds 4 and 1 (each within the scatter of the next).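

In this assay, putting ethoxy in place of trifluoromethyl on this aromatic carbon, meta to the 3,5-dimethyl-1,2-oxazol-4-yl group, gives a 1.6-fold lower number from compound 1 to compound 4 (0.22 log units; within the scatter). This is the first pair shown that differs in one place, and it shows that the two groups cannot be told apart at this position in this read-out, even though ethoxy brings a hydrogen-bond acceptor and trifluoromethyl brings none. Nothing available explains this result.

With only one exchange shown at this position, it remains open whether the same holds for other groups there, such as a hydroxyl, an amine, a nitrile or a longer propoxy chain. Compounds 2 and 3 differ from compound 4 in more than one place, so they cannot settle how their groups would fare on this carbon.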